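The source may report more compounds than this note shows. Statements on the series, on what has been measured and on what is new or still open speak of the compounds shown alone.

Measured compounds:
compound 1 `O=C1O/C(=C\Cn2cc(-c3ccc(Br)cc3)nn2)C(OCc2ccccc2)=C1OCc1ccccc1` — > 100000 nM
compound 2 `O=C1O[C@H]([C@@H](O)Cn2cc(C3CC3)nn2)C(OCc2ccccc2)=C1OCc1ccccc1` — 43900 nM

In a functional assay on A549 cells (Homo sapiens) for antiproliferative activity, read by MTT assay, with a stated time of 72 h (on this read-out lower numbers stand for stronger inhibition and higher numbers for weaker inhibition), compound 1 gives > 100000 nM; this is a limit of the assay and not a number, so compound 1 stands only at the limit of > 100000 nM in this assay, at which 1 of the 2 values shown sits. Compound 2 in this assay gives 43900 nM. No step between two measured compounds is shown. Compound 3 `O=C1O/C(=C\Cn2cc(-c3cccc(O)c3)nn2)C(OCc2ccccc2)=C1OCc1ccccc1` differs from compound 1 by 3-hydroxyphenyl in place of 4-bromophenyl on an aromatic carbon. The step from compound 1 to compound 3 is expected to be an at least 1.2-fold lower number from compound 1 to compound 3 (0.09 log units; that floor lies within the scatter), that is, no change beyond the usual scatter. Compound 3 is therefore estimated at 80000 nM, with a range from 20000 nM to 300000 nM.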

Compound 3, half-maximal inhibitory concentration: 23300 nM
Compound 3: the middle estimate sits 3.4-fold (0.54 log units) above what was measured, within the range that was stated.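

At this aromatic carbon, putting 3-hydroxyphenyl in place of 4-bromophenyl gives a change that can be read in this assay, namely an at least 4.2-fold lower number from compound 1 to compound 3 (0.63 log units; beyond the scatter). The group at this position therefore matters for activity in these cells. The entry for compound 1 is a limit of the assay and not a number: the limit of > 100000 nM in this assay, at which 1 of the 3 values shown sits.

This single swap removes the bromine, adds the hydroxyl and moves the substituent on the phenyl ring, and the compounds shown do not separate these changes. On these data alone, how an amine or a carboxylic acid on the phenyl ring would behave also stays open.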